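The source may report more compounds than this note shows. Statements on the series, on what has been measured and on what is new or still open speak of the compounds shown alone.

Of the compounds shown here, three on a shared core have been measured in a functional assay on PBMC cells (Homo sapiens) for inhibition, read by HTRF, with stated times of 15 min and 24 h; a higher number here means a weaker inhibitor, a lower number a stronger inhibitor. Compound 1 (`O=C(Nc1ccc2c(c1)B(O)OC2)c1ccccc1C(F)(F)F`) gives 2100 nM there and compound 3 (`O=C(Nc1ccc2c(c1)B(O)OC2)c1c(F)cccc1C(F)(F)F`) gives 180 nM there. Compound 2 (`O=C(Nc1ccc2c(c1)B(O)OC2)c1ccccc1F`) stands at > 10000 nM and this is a limit of the assay, not a number. Compound 4 (`O=C(Nc1ccc2c(c1)B(O)OC2)c1cc(C(F)(F)F)ccc1F`) differs from compound 2 by one change (trifluoromethyl in place of hydrogen on an aromatic carbon), with trifluoromethyl in place of hydrogen on an aromatic carbon, meta to a large group and para to a fluoro group.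

The closest measured step is the same exchange of hydrogen for trifluoromethyl, an at least 55-fold lower number from compound 2 to compound 3 (1.74 log units; beyond the scatter) and large, although compound 3 carries the group at another place than compound 4 does. Two further steps point the same way. Losing trifluoromethyl for fluoro gave an at least 4.7-fold higher number from compound 1 to compound 2 (0.67 log units; beyond the scatter) and having both groups together gave a 12-fold lower number from compound 1 to compound 3 (1.07 log units; beyond the scatter) as well. Both compounds with a trifluoromethyl group give a number, and compound 2 without one does not. A clearly lower number is therefore expected in this assay for compound 4, but with the size uncertain, since the place of the group is new. The expected change is an at least 6.6-fold lower number from compound 2 to compound 4 (0.82 log units; beyond the scatter) by this estimate. Compound 4 is estimated at 1500 nM with an expected range from 300 nM to 8000 nM in this assay.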

Compound 4, half-maximal inhibitory concentration: > 100000 nM
Compound 4 gave a limit, no number; the forecaster's own chance of this, stated with the estimate: 20%; at least 66-fold (1.82 log units) between middle value and limit.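

In this assay compound 4 gives > 100000 nM, a limit and not a number. Compound 2 gives > 10000 nM, also a limit, so no step can be read between compound 2 and compound 4. The compounds shown leave open whether trifluoromethyl at the place it holds in compound 4 changes the number at all.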